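The source may report more compounds than this note shows. Statements on the series, on what has been measured and on what is new or still open speak of the compounds shown alone.

Working notes on the series

Going by the values given here, in a functional assay on Caco-2 cells (Homo sapiens) for cytotoxicity, with a stated time of 24 h (a lower number here means a stronger inhibitor, a higher number a weaker inhibitor), compound 2 `Cc1ccc(NC(=O)c2c(-c3ccccc3)c(-c3ccccc3)nn2-c2ccccc2)cc1` gives 2.21 ug/mL, the highest of the three numbers measured so far. Compound 1 `O=C(Nc1ccccc1)c1c(-c2ccc(Cl)cc2)c(-c2ccccc2)nn1-c1ccccc1` gives 1.74 ug/mL in this assay, a number within the scatter of that for compound 2, so no order between these two can be claimed. Compound 3 `Cc1ccc(NC(=O)c2c(-c3ccccc3)c(-c3ccc(Cl)cc3)nn2-c2ccccc2)cc1` gives 0.67 ug/mL, and the step of a 3.3-fold lower number from compound 2 to compound 3 (0.52 log units; beyond the scatter) is the only one in the set that reaches beyond the scatter.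

Compound 4 `Cc1ccc(NC(=O)c2c(-c3ccc(Cl)cc3)c(-c3ccccc3)nn2-c2ccccc2)cc1` has not yet been measured in this assay. Relative to compound 2 the change is chloro in place of hydrogen on an aromatic carbon, on the six-membered aromatic ring of carbon only that sits para to a large group; read one bond further out, it is phenyl to 4-chlorophenyl. Among the compounds with values here, the one measured step that bears on it, the one from compound 2 to compound 3, places the same chloro-for-hydrogen exchange on the other aryl ring of the shared core and moved the number down by a modest amount. Compound 1 carries chloro on the same ring as compound 4 does but differs from compound 2 in a second place as well, so its value can only be set next to that of compound 2 without a step.

On this basis a downward step is expected for compound 4, of roughly the size a 1.8-fold lower number from compound 2 to compound 4 (0.27 log units; within the scatter), though whether the second ring responds like the first is not shown. Compound 4 is therefore estimated at 1.2 ug/mL, with a range from 0.5 ug/mL to 2.8 ug/mL.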

Compound 4, half-maximal inhibitory concentration: 1.54 ug/mL
The estimate for compound 4 lay 1.3-fold (0.11 log units) below the measured number, within the range that was stated.
By their numbers in this assay, from the lowest: compound 3; then compounds 4, 1 and 2 (each within the scatter of the next).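

In this assay, chloro in place of hydrogen on this six-membered aromatic ring, para to a large group, gives a 1.4-fold lower number from compound 2 to compound 4 (0.16 log units; within the scatter), so no change can be claimed for phenyl to 4-chlorophenyl at this position, whereas the same exchange on the other aryl ring of the shared core gives a 3.3-fold lower number from compound 2 to compound 3 (0.52 log units; beyond the scatter). Going by these compounds alone, the new value also gives the first single-place reading of an added methyl, a 1.1-fold lower number from compound 1 to compound 4 (0.05 log units; within the scatter), so with chloro held on this ring, no order can be claimed between the compounds with and without the methyl. No supporting data bear on these results, and the contrast between the two aryl rings remains unexplained.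

From the compounds shown here alone, whether this position stays as flat for other groups remains open, for example with an amine or a carboxylic acid in place of chloro. Also open, going by these compounds, is how a compound carrying 4-chlorophenyl on both aryl rings of the shared core would compare with compound 3.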